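This account rests on a few compounds, and the source may have more. Where it says the series, first, only, none or still open, it means among the compounds named here.

Measured so far in a functional assay on HepG2 cells (Homo sapiens) for antiproliferative activity, read by MTT assay; a higher number here means a weaker inhibitor, a lower number a stronger inhibitor:
- compound 1, `CC1(C)CCc2c(ccc(C(=O)/C=C/c3ccc(OCc4cn(-c5ccc(Cl)cc5)nn4)cc3)c2O)O1`: 102000 nM
- compound 2, `CC1(C)CCc2cc(C(=O)/C=C/c3ccc(OCc4cn(Cc5ccc([N+](=O)[O-])cc5)nn4)cc3)c(O)cc2O1`: 109000 nM
- compound 3, `CCCCCn1cc(COc2ccc(/C=C/C(=O)c3cc4c(cc3O)OC(C)(C)CC4)cc2)nn1`: 95800 nM

All three numbers sit within the usual scatter of one another, so compound 1 is neither the weaker nor the stronger of the set; its number lies alongside those of compound 3 and compound 2 with no resolved gap. Among the measured compounds shown here, the only single-point step among them, a 1.1-fold lower number from compound 2 to compound 3 (0.06 log units; within the scatter), exchanges an aromatic group for a chain at the far end of the molecule and leaves the number where it was.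

Compound 4, `CCCCCCCCn1cc(COc2ccc(/C=C/C(=O)c3ccc4c(c3O)CCC(C)(C)O4)cc2)nn1`, is the next compound to be measured. It differs from compound 1 by octyl in place of 4-chlorophenyl on an aromatic nitrogen. This again trades an aromatic group for a plain chain on the same end of the molecule as in the step from compound 2 to compound 3, though here directly on the ring nitrogen rather than on a chain carbon. That step bears on it and was within the scatter, so no step beyond the scatter is expected in this assay, and a 1.0-fold lower number from compound 1 to compound 4 (0.01 log units; within the scatter) is the expectation. Compound 4 is accordingly estimated at 100000 nM, in the range 55000 nM to 180000 nM.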

Compound 4, half-maximal inhibitory concentration: 74100 nM
The estimate for compound 4 lay 1.3-fold (0.13 log units) above the measured number, within the range that was stated.
By their numbers in this assay, from the lowest: compounds 4, 3, 1 and 2 (each within the scatter of the next).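

In this assay, octyl in place of 4-chlorophenyl on the aromatic nitrogen gives a 1.4-fold lower number from compound 1 to compound 4 (0.14 log units; within the scatter), so removing the carbon-only aromatic ring from this position in favour of a plain chain opens no gap beyond the scatter. The earlier step made a comparable exchange only on a saturated chain carbon bound to the aromatic nitrogen; this one shows the same lack of a resolved difference with the group attached directly to that nitrogen. No measurement here offers a reason for this result.

With every step so far within the scatter, the compounds shown do not establish that the group at this position can shift the number at all. Going by these compounds, whether a primary amine or a carboxylic acid on the end of the chain would open a resolved gap stays open.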